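The source may hold more compounds than are shown below. What is called first, only, known or untested is meant among the compounds shown, and "the series" means these compounds.

Measured in a functional assay on SK-OV-3 cells (Homo sapiens) for cytotoxicity, read by sulforhodamine B assay, with a stated time of 48 h, tested at 0.1 uM; a higher number here means a weaker effect of the compound at the concentration tested, a lower number a stronger effect:
- compound 1 `COc1cc(-c2cc(/C=C/C(=O)c3ccc(N)cc3)[nH]n2)cc(OC)c1OC` gives 98%
- compound 2 `COc1cc(-c2cc(/C=C/C(=O)c3ccc(Cl)c(Cl)c3)[nH]n2)cc(OC)c1OC` gives 104%
- compound 3 `COc1ccc(C(=O)/C=C/c2cc(-c3cc(OC)c(OC)c(OC)c3)n[nH]2)cc1OC` gives 105%

Compound 3 stands highest of the three numbers, but its nearest neighbour compound 2 is separated only by a number 1 percentage points higher from compound 2 to compound 3 (within the scatter) and the furthest, compound 1, only by a number 7 percentage points higher from compound 1 to compound 3 (within the scatter), so the three values cannot be ordered. Every measured step exchanges the aryl group on the carbonyl carbon: a number 6 percentage points higher from compound 1 to compound 2 (within the scatter), a number 7 percentage points higher from compound 1 to compound 3 (within the scatter), a number 1 percentage points higher from compound 2 to compound 3 (within the scatter), none beyond the scatter.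

Compound 4 `COc1ccc(C(=O)/C=C/c2cc(-c3cc(OC)c(OC)c(OC)c3)n[nH]2)cc1` differs from compound 3 as follows: hydrogen in place of methoxy on an aromatic carbon. This change sits in the same aryl group that the measured steps varied without effect, so the step from compound 3 to compound 4 is expected to be a number 2 percentage points lower from compound 3 to compound 4 (within the scatter), not beyond the scatter. Compound 4 is therefore estimated at 103%, with a range of 92% to 112%.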

Compound 4, a percentage reported as activity, at one concentration (the size of the read-out at that concentration, not a potency): 99%
Estimate against measurement, compound 4: 4 percentage points above; low and high end bracket the measured number.
By their numbers in this assay, from the lowest: compounds 1, 4, 2 and 3 (each within the scatter of the next).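

Hydrogen in place of methoxy, which turns 3,4-dimethoxyphenyl into 4-methoxyphenyl, leaves no readable change in this assay (a number 6 percentage points lower from compound 3 to compound 4 (within the scatter)). Within the data shown here, the single methoxy group therefore adds a further aryl group that cannot be separated from the dichloro or amino analogues (a number 5 percentage points lower from compound 2 to compound 4 (within the scatter); a number 1 percentage points higher from compound 1 to compound 4 (within the scatter)). Nothing available explains this flat response.

Still open, from the compounds shown here alone, is whether a carboxylic acid or a morpholine on this aromatic carbon would move the number beyond the scatter. Also open, going by these compounds, is whether the same aryl exchanges would separate at another concentration.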